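Replacing a carboxylic acid by an amino alcohol side chain

The source may report more compounds than this note shows. Statements on the series, on what has been measured and on what is new or still open speak of the compounds shown alone.

Measured compounds:
- compound 1, `COc1ccc(-c2cc(-c3ccccc3)no2)c(OCCCN2CCCCC2)c1`, 15%
- compound 2, `COc1ccc(-c2cc(-c3ccccc3)no2)c(OCC(O)CN2CCCCC2)c1`, 16.8%
- compound 3, `COc1ccc(-c2cc(-c3ccccc3)no2)c(OCC(=O)O)c1`, "not determined" (no result reported)

All three share one core and differ only in the side chain attached through an oxygen on the aromatic ring. In a functional assay on the whole organism (blood, strain Sprague-Dawley albino) with Rattus norvegicus as the target, with stated times of 30 min and 24 h, at a dose of 100 mg/kg by the oral route (a higher number here means more inhibition at the dose given (going by the name of the read-out), a lower number less inhibition), compound 1 gives 15%, and compound 2 gives 16.8%. For the measured compounds named here, the only single-point step among them, a number 1.8 percentage points higher from compound 1 to compound 2 (within the scatter), shows that adding a hydroxy group to the chain changed nothing that can be told from the scatter. Compound 3 carries a carboxy group on that chain, and for it the result in this assay is "not determined" (no result reported), so it cannot be placed against the other two.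

Compound 4, `CCN(CC)CC(O)COc1cc(OC)ccc1-c1cc(-c2ccccc2)no1`, arises from compound 3 by the change (2-(diethylamino)-1-hydroxyethyl in place of carboxy on a saturated chain carbon bound to an oxygen on an aromatic ring). Its side chain is close in kind to that of compound 2, with a diethylamino group where compound 2 carries its ring amine. Going by the values given here, no measured step mirrors this change, so the expectation rests on compounds 1 and 2 sitting at a similar low level. Compound 4 is therefore expected to give about 16% in this assay, within a range from 4% to 30%.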

Compound 4, a percentage reported as inhibition, in the whole organism at one dose (the size of the read-out at that dose, not a potency): 11.4%
For compound 4 the middle estimate is 4.6 percentage points above the measured one; measured number inside the range.
By their numbers in this assay, from the lowest: compounds 4, 1 and 2 (each within the scatter of the next).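

In this assay, putting diethylamino in place of piperidin-1-yl gives a number 5.4 percentage points lower from compound 2 to compound 4 (within the scatter) and so, at this dose, the open-chain amine and the ring amine cannot be told apart. The wider change, 2-(diethylamino)-1-hydroxyethyl in place of 2-(piperidin-1-yl)ethyl on a saturated chain carbon bound to an oxygen on an aromatic ring, gives a number 3.6 percentage points lower from compound 1 to compound 4 (within the scatter) and so changing the amine and adding the hydroxy group together still produce no step beyond the scatter. Nothing on hand explains why these steps are so small.

Every amine-bearing chain shown ends in a tertiary amine, so it stays open whether a morpholine ring or a simple methylamino group would read differently. As far as these compounds go, it also stays open whether a longer chain would move the result, or whether an amide in place of the amine would.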